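The source may hold more compounds than are shown below. What is called first, only, known or untested is meant among the compounds shown, and "the series" means these compounds.

The series shares one core, varied at one aromatic carbon and at the group on the thiocarbonyl carbon. Compound 1 `N/C(=N\NC(=S)N1CCOCC1)c1ccccn1` gives 43.1% in a functional assay on A-431 cells (Homo sapiens) for cytotoxicity, read by MTT assay, with a stated time of 72 h, tested at 3 uM; a lower number here means less inhibition of growth, a higher number more inhibition of growth at the concentration tested. Compound 2 `Cc1ccnc(/C(N)=N/NC(=S)N2CCOCC2)c1` gives 35.5% in this assay, and compound 3 `Cc1ccnc(/C(N)=N/NC(=S)N2CCN(c3ccccn3)CC2)c1` gives 34.7% there. On these three numbers compound 2 stands second highest; compound 3 lies nearest to it, within the scatter, and compound 1, the furthest, is also within the scatter. Among the compounds with values here, the only single-place step between measured compounds runs from compound 1 to compound 2, a methyl in place of hydrogen on an aromatic carbon, and it amounts to a number 7.6 percentage points lower from compound 1 to compound 2 (within the scatter), within the scatter.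

Compound 4 `Cc1ccnc(/C(N)=N/NC(=S)N2CCSCC2)c1` differs from compound 2 in one place: thiomorpholin-4-yl in place of morpholin-4-yl on a thiocarbonyl carbon. Within the data shown here, no measured step bears directly on this exchange; the ring change seen in compound 3 goes to a different ring, and the number of compound 3 sits within the scatter of that of compound 2. The account therefore expects the estimated step of a number 2.5 percentage points higher from compound 2 to compound 4 (within the scatter) in this assay, nothing beyond the scatter in either direction. Compound 4 is expected to give 38%, within a range from 25% to 52%.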

Compound 4, percent growth inhibition at one concentration: 34.7%
The estimate for compound 4 lay 3.3 percentage points above the measured number, within the range that was stated.
By their numbers in this assay, from the lowest: compounds 3, 4, 2 and 1 (each within the scatter of the next).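

On the thiocarbonyl carbon, thiomorpholin-4-yl in place of morpholin-4-yl gives a number 0.8 percentage points lower from compound 2 to compound 4 (within the scatter) in this assay and so leaves the number within the scatter. Within the data shown here, the only step that could be read before this one lay on an aromatic carbon, so this is the first reading of an exchange at the thiocarbonyl carbon, and it sets the two rings, which have the same size and differ in one hetero atom, apart by nothing beyond the scatter. Nothing given here bears on why the two groups read alike.

The compounds shown leave open whether the same exchange would also stay within the scatter on the core of compound 1, which lacks the methyl, and whether a ring with carbon in place of the second hetero atom, such as piperidin-1-yl, or an open-chain group such as dimethylamino would behave in the same way on the thiocarbonyl carbon. They also leave open what a methoxy group or a chlorine atom in place of the methyl on the aromatic carbon would give in this assay at this single tested concentration.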